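The compounds below may be only part of what the source reports. "The series", "measured", "known", "first", "only" and "open" are said of these compounds alone.

Notes on the nitrogen substituent of the shared core.

Three compounds of the series have numbers in an assay on Prostate gland for inhibition of steroid 5-alpha-reductase (Rattus norvegicus); a lower number here means a stronger inhibitor, a higher number a weaker inhibitor. Compound 1 `CCCn1ccc2cc(/C(C)=C/C(=O)Nc3ccccc3OCCCC(=O)O)ccc21` gives 190 nM. Compound 2 `C/C(=C\C(=O)Nc1ccccc1OCCCC(=O)O)c1ccc2c(ccn2CC(C)C)c1` gives 160 nM, and compound 3 `CCCC(CC)n1ccc2cc(/C(C)=C/C(=O)Nc3ccccc3OCCCC(=O)O)ccc21` gives 9.3 nM. Compound 2 thus stands second highest of the three; its nearest neighbour is compound 1, as a 1.2-fold lower number from compound 1 to compound 2 (0.07 log units; within the scatter) shows, and its furthest is compound 3, the gap being a 17-fold lower number from compound 2 to compound 3 (1.24 log units; beyond the scatter).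

Compound 4 `C/C(=C\C(=O)Nc1ccccc1OCCCC(=O)O)c1ccc2c(ccn2Cc2ccccc2C)c1` is not yet measured. Against compound 2 the change is 2-methylphenyl in place of isopropyl on a saturated chain carbon bound to an aromatic nitrogen.

Within the data shown here, two measured steps bear on the matter, both on the group carried by the aromatic nitrogen. From compound 1 to compound 3 the change was a 20-fold lower number from compound 1 to compound 3 (1.31 log units; beyond the scatter), and from compound 2 to compound 3 it was a 17-fold lower number from compound 2 to compound 3 (1.24 log units; beyond the scatter). Both show that enlarging the group on the aromatic nitrogen brings a large drop in this assay. Among the measured compounds shown here, compound 4 enlarges that group in a different way, with a ring rather than a longer chain, so the data give no direct precedent; a drop is expected, though with less confidence than for compound 3, and a smaller one than a 17-fold lower number from compound 2 to compound 3 (1.24 log units; beyond the scatter).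

The estimated step from compound 2 to compound 4 is a 4.6-fold lower number from compound 2 to compound 4 (0.66 log units; beyond the scatter). Compound 4 is therefore expected to give 35 nM in this assay, in a range from 8 nM to 150 nM.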

Compound 4, half-maximal inhibitory concentration: 69 nM
Estimate against measurement, compound 4: 2.0-fold (0.29 log units) below, and the stated range covers the measured number.
By their numbers in this assay, from the lowest: compound 3; then compound 4; then compounds 2 and 1 (each within the scatter of the next).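

In this assay the group on the saturated chain carbon bound to an aromatic nitrogen proves open to a ring as well as to a chain: 2-methylphenyl in place of isopropyl gives a 2.3-fold lower number from compound 2 to compound 4 (0.37 log units; beyond the scatter) as a modest gain, and 2-methylphenyl in place of ethyl gives a 2.8-fold lower number from compound 1 to compound 4 (0.44 log units; beyond the scatter) as a gain of similar kind. The ring does not match the branched chain, since 2-methylbenzyl in place of 1-ethylbutyl on the aromatic nitrogen gives a 7.4-fold higher number from compound 3 to compound 4 (0.87 log units; beyond the scatter) and so leaves compound 3 the strongest inhibitor of the four. No measurement shown accounts for this ordering of the groups on the aromatic nitrogen.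

The compounds shown leave open whether the methyl on the ring contributes to the gain and whether the ring must be aromatic, questions that a plain benzyl group and a cyclohexylmethyl group on the aromatic nitrogen would address. They also leave open whether a larger branched chain such as 1-propylbutyl would go beyond 1-ethylbutyl at this position.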